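Changing the benzyl substituent with cytotoxicity still beyond reach

The source may report more compounds than this note shows. Statements on the series, on what has been measured and on what is new or still open speak of the compounds shown alone.

Compound 2 `CCOC(=O)c1cnc(N2CCN(Cc3ccc(C(F)(F)F)cc3)CC2)nc1Oc1c(C)cc(-c2ccc(C#N)cc2)cc1C` was tested in an ADME assay on MT4 cells (Homo sapiens) for cytotoxicity, read by MTT assay, with a stated time of 4 days; a lower number here means that less compound is tolerated, a higher number that more compound is tolerated. For compound 2 the result is a limit of the assay, not a number: > 125000 nM. Compound 1 `CCOC(=O)c1cnc(N2CCN(Cc3ccc(C#N)cc3)CC2)nc1Oc1c(C)cc(-c2ccc(C#N)cc2)cc1C` likewise reached only a limit, > 125000 nM. Compound 3 `CCOC(=O)c1cnc(N2CCN(Cc3ccccc3[N+](=O)[O-])CC2)nc1Oc1c(C)cc(-c2ccc(C#N)cc2)cc1C` also ended at a limit, >= 78700 nM. Compound 2 thus stands at the limit of > 125000 nM in this assay, at which 2 of the 3 values shown sit, while the remaining value sits at the limit of >= 78700 nM in this assay, at which 1 of the 3 values shown sits. Compound 4 `CCOC(=O)c1cnc(N2CCN(Cc3cccc(C(N)=O)c3)CC2)nc1Oc1c(C)cc(-c2ccc(C#N)cc2)cc1C` differs from compound 2 by 3-carbamoylphenyl in place of 4-(trifluoromethyl)phenyl on a saturated chain carbon bound to an amine nitrogen in a ring. Going by the values given here, the steps that bear on this change, a step that the two limits leave unreadable from compound 1 to compound 2, a step that the two limits leave unreadable from compound 1 to compound 3 and a step that the two limits leave unreadable from compound 2 to compound 3, each run between two limits and show no readable size. No change beyond the scatter is therefore expected in this assay . Compound 4 is expected to give 125000 nM, within 80000 nM to 200000 nM. The implied step, a number no higher from compound 2 to compound 4 (the limit leaves the size open), is expected to remain unreadable as well.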

Compound 4, half-maximal cytotoxic concentration: 14800 nM
Beside the measured number, compound 4's estimate is 8.4-fold (0.93 log units) above it; the measured number lies below the stated range.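

In this assay, the benzyl group turns out to matter: moving to 3-carbamoylbenzyl brings an at least 8.4-fold lower number from compound 2 to compound 4 (0.92 log units; beyond the scatter), an at least 8.4-fold lower number from compound 1 to compound 4 (0.92 log units; beyond the scatter) and an at least 5.3-fold lower number from compound 3 to compound 4 (0.72 log units; beyond the scatter). Compound 4 is the only compound shown that gives a number rather than a limit, and its 3-carbamoylphenyl carries a hydrogen-bond donor where the 4-(trifluoromethyl)phenyl of compound 2 carries none. Nothing measured here gives a cause for this drop. From the compounds shown here alone, whether the carbamoyl group itself or its place on the ring counts stays open, as does whether a carboxylic acid or an amine on the benzyl ring would also lower the number.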